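Heteroaryl variation on the cyclopropane carbon of the series

A few compounds are considered here, and "the series" means these few. Any claim that something is new, unique, unknown or untested is made for them only; others in the source may bear on it.

Measured so far, in a functional assay for agonist activity at G protein-coupled receptor 88 (Homo sapiens), read by HTRF and cAMP accumulation; a lower number here means that less compound is needed, a higher number that more compound is needed for the effect:
compound 1, `CC[C@H](C)[C@H](N)CN(C(=O)[C@@H]1C[C@H]1c1cccc(OC)c1)c1ccc(-c2ccccc2)cc1`, 3000 nM
compound 2, `CC[C@H](C)[C@H](N)CN(C(=O)[C@@H]1C[C@H]1c1ccncc1)c1ccc(-c2ccccc2)cc1`, 1500 nM
compound 3, `CC[C@H](C)[C@H](N)CN(C(=O)[C@@H]1C[C@H]1c1ccoc1)c1ccc(-c2ccccc2)cc1`, 580 nM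

Compound 3 gives the lowest number of the three. The gaps are a 2.6-fold lower number from compound 2 to compound 3 (0.41 log units; beyond the scatter) and a 5.2-fold lower number from compound 1 to compound 3 (0.71 log units; beyond the scatter), both beyond the scatter, so compound 3 stands apart as the most potent of the measured set. Between the other two the change is a 2.0-fold lower number from compound 1 to compound 2 (0.30 log units; within the scatter), within the scatter.

Compound 4, `CC[C@H](C)[C@H](N)CN(C(=O)[C@@H]1C[C@H]1c1nc(C)cs1)c1ccc(-c2ccccc2)cc1`, is not yet measured. It differs from compound 3 by 4-methyl-1,3-thiazol-2-yl in place of furan-3-yl on a saturated ring carbon. Within the data shown here, the steps that bear on this are the two arriving at compound 3, both of which show that swapping the aryl group at this position can move the number by a modest amount. Among the measured compounds shown here, no measured step involves a 1,3-thiazole, so the direction of this change is open. Compound 4 is estimated to come out slightly weaker than compound 3, at 900 nM with a range of 300 nM to 3000 nM, meaning an expected step of a 1.6-fold higher number from compound 3 to compound 4 (0.19 log units; within the scatter).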

Compound 4, half-maximal effective concentration: 730 nM
Estimate against measurement, compound 4: 1.2-fold (0.09 log units) above; low and high end bracket the measured number.
By their numbers in this assay, from the lowest: compounds 3 and 4 (each within the scatter of the next); then compounds 2 and 1 (each within the scatter of the next).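

In this assay, 4-methyl-1,3-thiazol-2-yl on this saturated ring carbon cannot be told apart from furan-3-yl, with a 1.3-fold higher number from compound 3 to compound 4 (0.10 log units; within the scatter), so the best numbers at this position are not tied to a single ring. The same group also gives a 2.1-fold lower number from compound 2 to compound 4 (0.31 log units; beyond the scatter) and a 4.1-fold lower number from compound 1 to compound 4 (0.61 log units; beyond the scatter), which means that two five-membered aromatic rings with different hetero atoms both give lower numbers than pyridin-4-yl and 3-methoxyphenyl. Nothing at hand bears on what lies behind these differences.

The compounds shown leave open how much of the thiazole result belongs to the ring and how much to its methyl group, as the change from furan-3-yl alters both at once. Also open, on these data alone, is whether a larger substituent on the five-membered ring, such as an ethyl group, a primary amine or a carboxylic acid, would keep the number in this range.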